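Chloro in Place of Hydrogen: From Compound 2 to Compound 3

The source may report more compounds than this note shows. Statements on the series, on what has been measured and on what is new or still open speak of the compounds shown alone.

Measured compounds:
Compound 1, `Cc1ccc2[nH]c(C(=O)N[C@H]3CCN(S(=O)(=O)N4CCCCC4)C[C@@H]3C(=O)NCCN(C)C)cc2c1`: 105%
Compound 2, `O=C(N[C@H]1CN(S(=O)(=O)c2ccccc2)C[C@@H]1C(=O)N[C@H]1CCCNC1)c1cc(-c2ccccc2)on1`: 90%

Two compounds have been run in a functional assay on HEK293 cells for agonist activity at growth hormone secretagogue receptor type 1 (Homo sapiens), read by HTRF and inositol phosphate accumulation, with a stated time of 90 min, in the presence of a further agent that is not named here; a higher number here means a larger maximal response, a lower number a smaller maximal response. In this assay compound 1 reaches 105%, and compound 2 reaches 90%. Compound 2 thus stands lowest of the two numbers, and its gap to compound 1 is beyond the usual scatter of this assay.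

Compound 3, `O=C(N[C@H]1CN(S(=O)(=O)c2ccccc2)C[C@@H]1C(=O)N[C@H]1CCCNC1)c1cc(-c2ccccc2Cl)on1`, keeps the whole of compound 2 and differs from it in one place: chloro in place of hydrogen on an aromatic carbon. Among the compounds with values here, no pair of measured compounds shares this change, so the two values at hand say nothing directly about its effect on the maximal response.

The expectation for compound 3 is a step of no size beyond the scatter, no change at the digits printed from compound 2 to compound 3 (within the scatter), since nothing in the data points either way. Compound 3 is therefore estimated at 90%, with a range from 75% to 105%.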

Compound 3, largest response reached (Emax), in percent of the reference or control that the assay uses: 98%
For compound 3 the middle estimate is 8 percentage points below the measured one, and the stated range covers the measured number.
By their numbers in this assay, from the lowest: compounds 2, 3 and 1 (each within the scatter of the next, the first and the last beyond it).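

In this assay, the change from phenyl to 2-chlorophenyl gives a number 8 percentage points higher from compound 2 to compound 3 (within the scatter). Within the data shown here, this is the first reading at this position, and it shows that chloro in place of hydrogen on this aromatic carbon, ortho to a large group, leaves the maximal response within the scatter. No supporting measurement bears on this result.

The compounds shown leave open whether the same position would give a similar response with other groups, such as methyl, methoxy or an amine, in place of the chloro. A single pair also cannot show whether chloro would read alike at another carbon of this ring or on the other phenyl of compound 2.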